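This account rests on a few compounds, and the source may have more. Where it says the series, first, only, none or still open, it means among the compounds named here.

Of the compounds shown here, two sharing one core have been measured in a functional assay on A549 cells (Homo sapiens) for antiproliferative activity, read by MTT assay, with a stated time of 72 h; a lower number here means a stronger inhibitor, a higher number a weaker inhibitor: compound 1 `COc1cc(-n2cnc3ccc(-c4cccc(C)c4)cc32)cc(OC)c1OC` gives 3820 nM, and compound 2 `COc1cc(-n2cnc3ccc(-c4cccc(C)c4C)cc32)cc(OC)c1OC` gives 9250 nM. Compound 2 therefore holds the higher, weaker of the two numbers. Still unmeasured is compound 3 `COc1cc(-n2cnc3ccc(-c4cccc([N+](=O)[O-])c4)cc32)cc(OC)c1OC`, in which 3-nitrophenyl takes the place of 2,3-dimethylphenyl on an aromatic carbon (3-nitrophenyl in place of 2,3-dimethylphenyl on an aromatic carbon). Within the data shown here, only one measured step bears on this change: a 2.4-fold higher number from compound 1 to compound 2 (0.38 log units; beyond the scatter), modest but beyond the scatter, with methyl in place of hydrogen on an aromatic carbon. Among the measured compounds shown here, no compound with a nitro group has been measured, so this step is only a rough guide. Compound 3 lacks the second methyl of compound 2, as does compound 1 at 3820 nM, so a modest move to a lower number is expected in this assay. The expected step is a 2.3-fold lower number from compound 2 to compound 3 (0.36 log units; beyond the scatter). The estimated value for compound 3 is 4000 nM, within an expected range from 1300 nM to 12000 nM.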

Compound 3, half-maximal inhibitory concentration: 5410 nM
The estimate for compound 3 lay 1.4-fold (0.13 log units) below the measured number; the measured number falls inside the stated range.
By their numbers in this assay, from the lowest: compounds 1, 3 and 2 (each within the scatter of the next, the first and the last beyond it).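

In this assay, nitro in place of methyl on an aromatic carbon gives a 1.4-fold higher number from compound 1 to compound 3 (0.15 log units; within the scatter) and so does not separate compound 3 from compound 1 at this position. The change from 2,3-dimethylphenyl to 3-nitrophenyl gives a 1.7-fold lower number from compound 2 to compound 3 (0.23 log units; within the scatter) and also stays within the scatter, so compound 3 is not separated from compound 2 either, and only compound 1 and compound 2 remain apart. No measurement on hand accounts for these numbers. The compounds shown leave open whether an amine, a carboxylic acid or a methoxy group on this phenyl ring would give a number clearly apart from those of compound 1 and compound 3. They also leave open how a nitro group would read on another carbon of that ring.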